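The compounds below may be only part of what the source reports. "The series", "measured", "known", "first", "only" and "open" are said of these compounds alone.

Measured in a functional assay on HT-29 cells (Homo sapiens) for cytotoxicity, read by XTT assay, with a stated time of 72 h; on this read-out lower numbers stand for stronger inhibition and higher numbers for weaker inhibition:
- Compound 1 `C=C1CC[C@H]2C(C)(C)CCC[C@]2(C)[C@H]1CC/C(C)=C/Cc1c(O)cc(O)c2c(=O)c(O)c(-c3ccc(O)cc3)oc12`: 29000 nM
- Compound 2 `CC(C)=CCC/C=C(\C)Cc1c(O)cc(O)c2c(=O)c(OC/C=C(\C)CCC=C(C)C)c(-c3ccc(O)cc3)oc12`: 30000 nM
- Compound 3 `CC(C)=CCC/C(C)=C/COc1c(-c2ccc(O)cc2)oc2cc(O)cc(O)c2c1=O`: 25000 nM

These three numbers lie within the usual scatter of one another, so compound 2, at 30000 nM, cannot be separated from compound 1 or compound 3 in this assay.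

The next compound to be tested is compound 4 `CC(C)=CCC/C=C(\C)Cc1c(O)cc(O)c2c(=O)c(O)c(-c3ccc(O)cc3)oc12`, which has not yet been measured. It differs from compound 2 by one change: hydrogen in place of 3,7-dimethylocta-2,6-dien-1-yl on an oxygen on an aromatic ring. Put simply, the chain on the oxygen is removed and a hydroxy group is left in its place.

Among the compounds with values here, the one measured step that bears on this is a 1.2-fold lower number from compound 2 to compound 3 (0.08 log units; within the scatter). That step removes a chain from an aromatic carbon rather than from an oxygen, so it is only an indirect guide. Within the data shown here, no measured step shows what happens when a chain leaves an oxygen. Even so, the only chain removal measured so far did not move the number beyond the scatter, so no clear shift is expected in this assay here either.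

The expected size of the change is a 1.2-fold lower number from compound 2 to compound 4 (0.08 log units; within the scatter).

Compound 4 is estimated at 25000 nM, with an expected range from 12000 nM to 50000 nM.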

Compound 4, half-maximal inhibitory concentration: 30000 nM
Compound 4: the middle estimate sits 1.2-fold (0.08 log units) below what was measured, and the stated range covers the measured number.
By their numbers in this assay, from the lowest: compounds 3, 1, 2 and 4 (each within the scatter of the next).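

Within the data shown here, replacing the 3,7-dimethylocta-2,6-dien-1-yl chain on the oxygen on an aromatic ring with hydrogen gives no change at the digits printed from compound 2 to compound 4 (within the scatter) in this assay and so provides a direct reading at this oxygen, which the earlier compounds did not. Compound 2 can lose this chain of 10 carbon atoms with 2 double bonds and stay within the scatter, and the same holds for the chain on the aromatic carbon, where the step is a 1.2-fold lower number from compound 2 to compound 3 (0.08 log units; within the scatter) in this comparison. Taken one at a time, neither chain of compound 2 can be told apart from hydrogen in this cell read-out, and nothing measured here speaks to the reason.

From the compounds shown here alone, it remains open whether a different group on this oxygen, such as a methyl group, a chain ending in a carboxylic acid or a chain ending in an amine, would give a number beyond the scatter from compound 4. Going by these compounds, all four compounds carry a long chain in at least one of the two places, so it also remains open what a compound with hydrogen in both places would give.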